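The compounds below may be only part of what the source reports. "The series", "measured", "known", "first", "only" and "open" are said of these compounds alone.

Measured in an assay on isolated protein for inhibition of Amine oxidase [flavin-containing] B (Homo sapiens); on this read-out lower numbers stand for stronger inhibition and higher numbers for weaker inhibition:
- compound 1 `C#CCNC1CCc2c(SCc3cccc(OC)c3)cccc21`: 3190 nM
- compound 2 `C#CCNC1CCc2c(NCc3cccc(C(F)(F)F)c3)cccc21`: 5110 nM
- compound 3 `C#CCNC1CCc2c(SCCc3cccc(Cl)c3)cccc21`: 82400 nM

Compound 3 has the highest number of the three in this assay; both compound 2 and compound 1 sit at lower numbers, and each gap lies beyond the usual scatter. Compound 4 `C#CCNC1CCc2c(SCCc3ccc(F)c(F)c3)cccc21` has not been measured in this assay. It departs from compound 3 by one change: 3,4-difluorophenyl in place of 3-chlorophenyl on a saturated chain carbon, two bonds along the chain from a sulfur. Among the compounds with values here, no measured pair in the set isolates a swap of this kind, so there is no step to lean on. Any step from compound 3 to compound 4 in this assay is expected to be small and within the scatter, with the estimated step of a 1.2-fold lower number from compound 3 to compound 4 (0.07 log units; within the scatter). For compound 4 the expected value in this assay is 70000 nM, in a range from 20000 nM to 250000 nM.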

Compound 4, half-maximal inhibitory concentration: 3240 nM
Compound 4: the middle estimate sits 22-fold (1.33 log units) above what was measured; the measured number lies below the stated range.
By their numbers in this assay, from the lowest: compounds 1, 4 and 2 (each within the scatter of the next); then compound 3.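

In this assay, the aryl group on a saturated chain carbon, two bonds along the chain from a sulfur, proves highly sensitive to substitution: 3,4-difluorophenyl in place of 3-chlorophenyl gives a large step (a 25-fold lower number from compound 3 to compound 4 (1.41 log units; beyond the scatter)). The sulfur-linked two-carbon chain shared by compound 3 and compound 4 therefore does not by itself fix the high number of compound 3. Nothing available explains the size of this step.

Open: whether 3-fluorophenyl, 4-fluorophenyl or unsubstituted phenyl on this chain tracks compound 3 or compound 4. Also open, from the compounds shown here alone, is whether the step survives with an amine nitrogen in place of the sulfur.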